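Trifluoromethyl added to the aromatic ring of compound 3

The source may report more compounds than this note shows. Statements on the series, on what has been measured and on what is new or still open speak of the compounds shown alone.

Values so far in a functional assay on U-937 cells (Homo sapiens) for antiproliferative activity, read by MTT assay, with a stated time of 72 h; on this read-out lower numbers stand for stronger inhibition and higher numbers for weaker inhibition

- compound 1 `O=C(CCCCCCc1nc(-c2ccccc2Cl)no1)NO` gives 750 nM
- compound 2 `Nc1ccccc1NC(=O)CCCCCCc1nc(-c2ccccc2)no1` gives 730 nM
- compound 3 `O=C(CCCCCCc1nc(-c2ccccc2)no1)C(F)(F)F` gives 410 nM

Compound 3 lies within the scatter of both compound 1 and compound 2, so the three values do not separate in this assay. The next compound is compound 4 `O=C(CCCCCCc1nc(-c2ccc(C(F)(F)F)cc2)no1)C(F)(F)F`, which differs from compound 3 by one change on the aromatic ring: trifluoromethyl in place of hydrogen on an aromatic carbon.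

Among the compounds with values here, only one measured step links two compounds that differ in one place: a 1.8-fold lower number from compound 2 to compound 3 (0.25 log units; within the scatter). That step lies within the scatter, but it concerns the group on the carbonyl carbon and leaves the aromatic ring untouched. It therefore bears only indirectly on the new change. Within the data shown here, no measured step isolates a substituent on the aromatic ring, so the data give neither a size nor a direction for this change. The best anchor is compound 3 at 410 nM, with a wide margin on both sides.

No shift beyond the scatter is expected, and the estimated step is a 1.1-fold higher number from compound 3 to compound 4 (0.04 log units; within the scatter). For compound 4 the expected value is 450 nM, with an estimated range of 150 nM to 1300 nM.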

Compound 4, half-maximal inhibitory concentration: 1960 nM
Beside the measured number, compound 4's estimate is 4.4-fold (0.64 log units) below it, outside the stated range (above it).
By their numbers in this assay, from the lowest: compounds 3, 2 and 1 (each within the scatter of the next); then compound 4.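

In this assay, within the data shown here, the aromatic ring of the shared core proves sensitive to substitution: a 4.8-fold higher number from compound 3 to compound 4 (0.68 log units; beyond the scatter) is a shift beyond the scatter, whereas the only earlier single-place step, a 1.8-fold lower number from compound 2 to compound 3 (0.25 log units; within the scatter), stayed within it and left the ring untouched. At this position, on an aromatic carbon para to a large group, trifluoromethyl in place of hydrogen moves the read-out toward weaker inhibition, so the ring cannot be treated as a freely variable part of the series. No measured evidence bears on why this shift occurs.

As far as these compounds go, a single substituent at a single position gives a direction for trifluoromethyl only, so it remains open whether a smaller or different group at the same place, such as fluorine, methoxy, nitrile or an amine, would hold the number near that of compound 3 or raise it in the same way. From the compounds shown here alone, it is also open whether the same ring change would carry the same penalty in a compound with (2-aminophenyl)amino on the carbonyl carbon, as in compound 2, rather than trifluoromethyl.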